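Removing the bromo from compound 2: a step without precedent

The source may report more compounds than this note shows. Statements on the series, on what has been measured and on what is new or still open speak of the compounds shown alone.

Three compounds of this series have been run in a functional assay on DLD-1 cells (Homo sapiens) for cytotoxicity, read by colorimetric assay and MTT assay, with a stated time of 3 days, tested at 1 uM; a lower number here means a stronger effect, a higher number a weaker effect of the compound at the concentration tested. Compound 1 `COc1ccc(-c2nc(-c3ccccc3)c(-c3ccc4c(c3)NC(=O)CO4)[nH]2)cc1` gives 96%, compound 3 `O=C1COc2ccc(-c3[nH]c(-c4c[nH]c5ncccc45)nc3-c3ccccc3)cc2N1` gives 97.7%, and compound 2 `O=C1COc2ccc(-c3nn(-c4ccc(Br)cc4)cc3-c3ccccc3)cc2N1` gives 66.4%, the lowest of the three numbers, beyond the scatter from both others. Within the data shown here, the only measured step that changes one place, a number 1.7 percentage points higher from compound 1 to compound 3 (within the scatter), lies within the scatter and concerns a different part of the molecule than the one that now changes.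

Compound 4 `O=C1COc2ccc(-c3nn(-c4ccccc4)cc3-c3ccccc3)cc2N1` differs from compound 2 by hydrogen in place of bromo on an aromatic carbon. Among the measured compounds shown here, no measured step bears on this change; the halogen is not varied anywhere else, so nothing here shows whether the bromo carries the effect of compound 2. The estimate therefore leans towards a weaker effect with a wide range. For compound 4 the expected value in this assay is 78%, between 60% and 95%. The expected step is a number 11.6 percentage points higher from compound 2 to compound 4 (beyond the scatter), a move upward, though its size is uncertain.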

Compound 4, a percentage reported as activity, at one concentration (the size of the read-out at that concentration, not a potency): 77%
Estimate against measurement, compound 4: 1 percentage points above, within the range that was stated.
By their numbers in this assay, from the lowest: compound 2; then compound 4; then compounds 1 and 3 (each within the scatter of the next).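

In this assay, among these compounds, the change from 4-bromophenyl to phenyl gives the first measured step at this position, a number 10.6 percentage points higher from compound 2 to compound 4 (beyond the scatter), and it lies beyond the scatter. In this pair, then, the bromo on an aromatic carbon para to a large group goes with the lower number, although compound 4, which carries no halogen, still reads 77% at the single concentration tested. Nothing measured on hand gives a reason for this step.

Among the compounds shown here, the single pair leaves open whether the step is specific to bromine or would also appear with a chloro, a methoxy or an amine at the same place. It also leaves open whether hydrogen in place of bromo would give a step of similar size on another core, since this change is read here only on the shared core of compound 2 and compound 4.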